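The compounds below may be only part of what the source reports. "The series", "measured", "known", "first", "only" and "open" are said of these compounds alone.

Working notes on the series.

Three members of the series have been run in a functional assay on the whole organism for inhibition, with Rattus norvegicus as the target, read by paw edema, with stated times of 30 min and 4 h, at a dose of 0.28 mmol/kg by the oral route; a lower number here means less inhibition, a higher number more inhibition at the dose given (going by the name of the read-out). Compound 1, `CNC(=O)c1nc(-c2cc(OC)c(OC)c(OC)c2)n(-c2ccc(OC)cc2)n1`, gives 65%. Compound 2, `CCNC(=O)c1nc(-c2cc(OC)c(OC)c(OC)c2)n(-c2ccc(OC)cc2)n1`, gives 58%, and compound 3, `COc1ccc(-n2nc(C(=O)Nc3ccc(C)cc3)nc2-c2cc(OC)c(OC)c(OC)c2)cc1`, gives 58%. Compound 3 thus stands level with compound 2 and, together with it, at the lower end of the three numbers; the step of a number 7 percentage points lower from compound 1 to compound 3 (within the scatter) lies within the scatter, and the neighbouring step no change at the digits printed from compound 2 to compound 3 (within the scatter) is likewise within the scatter, as is a number 7 percentage points lower from compound 1 to compound 2 (within the scatter). All three measured steps alter only the group on the amide-type nitrogen.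

Compound 4, `COc1ccc(-n2nc(C(=O)Nc3ccc(C(=O)O)cc3)nc2-c2cc(OC)c(OC)c(OC)c2)cc1`, takes the step from compound 3 described as carboxy in place of methyl on an aromatic carbon. Among the compounds with values here, no measured step touches a substituent on the aromatic carbon of that six-membered ring, so none bears directly on this change; the measured steps only show that exchanges at the amide-type nitrogen leave this assay within the scatter. The working expectation is therefore a step of a number 3 percentage points lower from compound 3 to compound 4 (within the scatter) that does not exceed the scatter, with the direction left open. Compound 4 is accordingly estimated at 55%, with a range of 35% to 75%.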

Compound 4, a percentage reported as inhibition, in the whole organism at one dose (the size of the read-out at that dose, not a potency): 69%
Compound 4: the middle estimate sits 14 percentage points below what was measured; measured number inside the range.
By their numbers in this assay, from the lowest: compounds 2, 3, 1 and 4 (each within the scatter of the next, the first and the last beyond it).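

Carboxy in place of methyl on the aromatic carbon para to a large group is the first exchange in the series that goes beyond the scatter, with a number 11 percentage points higher from compound 3 to compound 4 (beyond the scatter) in this assay, and the 4-carboxyphenyl group on the amide-type nitrogen likewise separates from ethyl, with a number 11 percentage points higher from compound 2 to compound 4 (beyond the scatter). The separation does not extend to methyl on that nitrogen, since a number 4 percentage points higher from compound 1 to compound 4 (within the scatter), so the carboxy compound stands apart from the 4-methylphenyl and ethyl amides but not from the methyl amide. No measurement at hand accounts for the size or direction of this step.

The compounds shown leave open whether the higher number is tied to the carboxy group itself or would also appear with a methyl ester, a primary amide or an amine on the same aromatic carbon. They also leave open whether the step from methyl to carboxy would keep its direction and size at another dose, as each compound here is read at a single dose.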